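The compounds below may be only part of what the source reports. "The series", "measured", "known", "first", "only" and "open" are said of these compounds alone.

Working notes on the selenium-substituted series. Compound 1 `C[Se]c1nc([Se]C)c2cccnc2n1` carries two methylselanyl groups on the shared core; in a functional assay on CCRF-CEM cells (Homo sapiens) for cytotoxicity, read by MTT assay, with a stated time of 72 h (a higher number here means that more compound is tolerated, a lower number that less compound is tolerated), compound 1 gives "not determined" (no result reported), so no number is on hand for it. Compound 2 `Nc1nc([SeH])nc2ncccc12` carries an amine and an unsubstituted selenium; in this assay compound 2 gives 92100 nM. Compound 3 `CCCCC[Se]c1nc(N)c2cccnc2n1` carries the same amine with pentyl on the selenium; in this assay compound 3 gives 72600 nM. Within the data shown here, compound 3 and compound 2 lie within the scatter of each other, the only comparison the numbers allow, and the step of a 1.3-fold lower number from compound 2 to compound 3 (0.10 log units; within the scatter) shows that adding the pentyl chain moved the number no further than repeat measurements would.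

Compound 4 `C[Se]c1nc(N)c2cccnc2n1` is the next point: hydrogen in place of butyl on a saturated chain carbon bound to a selenium atom. Among the measured compounds shown here, the one measured step that bears on chain length at the selenium, a 1.3-fold lower number from compound 2 to compound 3 (0.10 log units; within the scatter), lies within the scatter, so shortening the chain from pentyl to methyl is expected to give no step beyond the scatter in this assay, a 1.1-fold higher number from compound 3 to compound 4 (0.04 log units; within the scatter). Compound 4 is therefore estimated at 80000 nM in this assay, with a range from 40000 nM to 160000 nM.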

Compound 4, concentration lethal to 50% of the cells: > 100000 nM
Compound 4 was reported as a limit; the forecaster's own chance of this, stated with the estimate: 5%; middle value at least 1.2-fold (0.09 log units) from the limit.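

Compound 4 is reported only as a limit and not as a number: the limit of > 100000 nM in this assay, at which 1 of the 4 values shown sits. With pentyl giving way to methyl on the selenium, the series shows an at least 1.3-fold higher number from compound 3 to compound 4 (0.13 log units; that floor lies within the scatter) and, set against the unsubstituted selenium, an at least 1.0-fold higher number from compound 2 to compound 4 (0.03 log units; that floor lies within the scatter) as its second reading. Both are floors with no upper end, whereas the step from compound 2 to compound 3 has a number at each end, so at this position a real rise on going to methyl can be neither claimed nor excluded.

The compounds shown leave open how a propyl chain or a benzyl group on the selenium would read in this assay and whether any group there gives a step beyond the scatter. They also leave open what a hydroxyl group in place of the amine would do.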